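Three Measured Compounds and a Fourth Awaiting Its Number

A few compounds are considered here, and "the series" means these few. Any claim that something is new, unique, unknown or untested is made for them only; others in the source may bear on it.

Compound 3 `CN(C)c1ccc(C2CC(c3ccc(-n4ccnc4)cc3)=NN2C(=O)c2ccc(F)cc2)cc1` gives 9.4% in a functional assay on MDA-MB-231 cells (Homo sapiens) for inhibition, read by sulforhodamine B assay, tested at 10 uM (a higher number here means more inhibition at the concentration tested (going by the name of the read-out), a lower number less inhibition), the highest of the three numbers; its nearest neighbour is compound 2 `CC(=O)N1N=C(c2ccc(-n3ccnc3)cc2)CC1c1ccc(N(C)C)cc1`, which gives 5%, and the furthest is compound 1 `CN1CCN(c2ccc(C3=NN(S(C)(=O)=O)C(c4ccc(N(C)C)cc4)C3)cc2)CC1`, which gives 0.6%, both gaps lying within the scatter. For the measured compounds named here, the single measured step, a number 4.4 percentage points higher from compound 2 to compound 3 (within the scatter), also lies within the scatter. Compound 4 `CN(C)c1ccc(C2CC(c3ccc(-n4ccnc4)cc3)=NN2S(C)(=O)=O)cc1` differs from compound 3 by methylsulfonyl in place of (4-fluorophenyl)carbonyl on an amine nitrogen in a ring. Going by the values given here, no measured step bears on this change directly; compound 1 carries the same methylsulfonyl on an amine nitrogen in a ring and shows a low number, and the one measured step was small. Compound 4 is therefore expected to stay within the scatter, an expected step of a number 6.4 percentage points lower from compound 3 to compound 4 (within the scatter), with an estimated value of 3%, ranging from -5% to 12%.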

Compound 4, a percentage reported as inhibition, at one concentration (the size of the read-out at that concentration, not a potency): 12%
Estimate against measurement, compound 4: 9 percentage points below; low and high end bracket the measured number.
By their numbers in this assay, from the lowest: compounds 1, 2, 3 and 4 (each within the scatter of the next, the first and the last beyond it).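

On the amine nitrogen in a ring, this assay does not separate methylsulfonyl from (4-fluorophenyl)carbonyl or acetyl, with a number 2.6 percentage points higher from compound 3 to compound 4 (within the scatter) and a number 7 percentage points higher from compound 2 to compound 4 (within the scatter). For the compounds shown here, with methylsulfonyl held at that position, 1H-imidazol-1-yl in place of 4-methylpiperazin-1-yl on an aromatic carbon gives a number 11.4 percentage points higher from compound 1 to compound 4 (beyond the scatter) and is the only new step of this size. No measurement at hand explains these results.

The compounds shown leave open how a longer chain in place of the methyl of methylsulfonyl would read, or a primary amine in place of 1H-imidazol-1-yl.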